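The source may report more compounds than this note shows. Statements on the series, on what has been measured and on what is new or still open speak of the compounds shown alone.

Going by the values given here, compound 2 `Cc1cc(/C=C/C#N)cc(C)c1Oc1cc(Nc2ccc(C#N)cc2)c(N)cc1C(=O)NCCC(F)F` holds the lower of the two numbers so far in an ADME assay on a cell-free system (plasma, Homo sapiens) for metabolic stability, read by LC-MS, tested at 10 ug/mL (on this read-out higher numbers stand for a longer-lived compound and lower numbers for a shorter-lived compound), giving 57 h, though within the scatter of compound 1 `Cc1cc(/C=C/C#N)cc(C)c1Oc1cc(Nc2ccc(C#N)cc2)c(N)cc1C(N)=O`, which in this assay gives 65 h. Among the compounds with values here, the single measured step is a 1.1-fold lower number from compound 1 to compound 2 (0.06 log units; within the scatter). Compound 3 `CNC(=O)c1cc(N)c(Nc2ccc(C#N)cc2)cc1Oc1c(C)cc(/C=C/C#N)cc1C` carries the change (hydrogen in place of 2,2-difluoroethyl on a saturated chain carbon bound to an amide-type nitrogen). That one step, which placed the whole 3,3-difluoropropyl on the amide-type nitrogen, left the number within the scatter, so cutting the chain back to methyl is expected to give no step beyond the scatter in this assay. Compound 3 is therefore estimated at 60 h, range 30 h to 120 h, a step of a 1.1-fold higher number from compound 2 to compound 3 (0.02 log units; within the scatter).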

Compound 3, half-life: 72 h
Beside the measured number, compound 3's estimate is 1.2-fold (0.08 log units) below it; the range from low to high includes it.
By their numbers in this assay, from the lowest: compounds 2, 1 and 3 (each within the scatter of the next).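

With methyl now on the amide-type nitrogen, this position has three substituents read in this assay (hydrogen, methyl and 3,3-difluoropropyl). Removing 2,2-difluoroethyl from the chain gives (a 1.3-fold higher number from compound 2 to compound 3 (0.10 log units; within the scatter)), and adding methyl to the unsubstituted amide gives (a 1.1-fold higher number from compound 1 to compound 3 (0.04 log units; within the scatter)), so neither the short nor the longer chain separates from the others. No measurement on hand accounts for these readings. As far as these compounds go, whether an amide-type nitrogen bearing a chain that ends in an amine or a carboxylic acid, or a cyclopropyl ring, would step beyond the scatter remains open.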